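Chlorophenyl isomer in the series: working notes

The source may report more compounds than this note shows. Statements on the series, on what has been measured and on what is new or still open speak of the compounds shown alone.

Values so far in an ADME assay on liver (Mesocricetus auratus) for metabolic stability, using microsomes (a lower number here means slower removal, a higher number faster removal of the compound), are these:
compound 1 `O=C(Nc1cc(-c2ccccn2)n[nH]1)N1CCC(c2ccc(F)cc2)CC1` gives 272 mL.min-1.g-1
compound 2 `O=C(Nc1cc(-c2ccccn2)n[nH]1)N1CCC(c2ccc(Cl)cc2)CC1` gives 43.8 mL.min-1.g-1

Compound 2 holds the lower of the two numbers. Chloro in place of fluoro on an aromatic carbon gave a 6.2-fold lower number from compound 1 to compound 2 (0.79 log units; beyond the scatter) and that step lies beyond the scatter. Compound 3 `O=C(Nc1cc(-c2ccccn2)n[nH]1)N1CCC(c2cccc(Cl)c2)CC1` carries 3-chlorophenyl in place of 4-chlorophenyl on a saturated ring carbon. Among the compounds with values here, the single measured step is the only one bearing on this change, and only loosely: it swapped the halogen, and no measured pair moves the chlorine. Within the data shown here, with a 6.2-fold lower number from compound 1 to compound 2 (0.79 log units; beyond the scatter) as the only guide, a smaller step is expected in this assay, leaning towards a higher number and not beyond the scatter. The expected step is a 1.5-fold higher number from compound 2 to compound 3 (0.17 log units; within the scatter) as an estimate. For compound 3 the estimated value is 65 mL.min-1.g-1 with an expected range from 22 mL.min-1.g-1 to 190 mL.min-1.g-1 as the estimate's limits.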

Compound 3, intrinsic clearance in microsomes: 63.5 mL.min-1.g-1
Compound 3: the middle estimate sits 1.0-fold (0.01 log units) above what was measured, and the stated range covers the measured number.
By their numbers in this assay, from the lowest: compounds 2 and 3 (each within the scatter of the next); then compound 1.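

In this assay, the change from 4-chlorophenyl to 3-chlorophenyl on the saturated ring carbon gives a 1.4-fold higher number from compound 2 to compound 3 (0.16 log units; within the scatter), so this read-out does not separate the two chlorine placements at this position. The halogen difference seen earlier is also not confined to 4-chlorophenyl: 3-chlorophenyl in place of 4-fluorophenyl gives a 4.3-fold lower number from compound 1 to compound 3 (0.63 log units; beyond the scatter), which leaves compound 1 set apart from the two chlorine compounds. No measured property at hand accounts for either step.

Still open, going by these compounds, is whether a methoxy group, a nitrile or a trifluoromethyl group in place of the chlorine would stay close to compound 2 and compound 3 or move towards compound 1. The same question holds for an unsubstituted phenyl group at this ring carbon.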